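The compounds below may be only part of what the source reports. "The series", "measured", "known", "first", "only" and "open" are said of these compounds alone.

Measured compounds:
- compound 1 `CCn1nc(-c2cccnc2)c2ccccc2c1=O`: 87%
- compound 2 `O=c1c2ccccc2c(-c2cccnc2)nn1C1CCCC1`: 97%
- compound 3 `O=c1c2ccccc2c(-c2cccnc2)nn1CC1CCCCC1`: 98%

In an assay on isolated protein (Oryctolagus cuniculus) with Thromboxane-A synthase (Homo sapiens) as the target, tested at 1 uM (on this read-out higher numbers stand for more inhibition at the one concentration tested (going by the name of the read-out) and lower numbers for less inhibition), compound 1 gives 87%, the lowest of the three numbers. The nearest is compound 2, reached by a number 10 percentage points higher from compound 1 to compound 2 (within the scatter), a move that stays within the scatter. The furthest is compound 3, reached by a number 11 percentage points higher from compound 1 to compound 3 (beyond the scatter), a move that lies beyond the scatter though still modest. Between compound 2 and compound 3 the step is a number 1 percentage points higher from compound 2 to compound 3 (within the scatter), within the scatter.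

Compound 4 `O=c1c2ccccc2c(-c2cccnc2)nn1Cc1cccc(Cl)c1` has not yet been measured in this assay. It differs from compound 1 in one place: 3-chlorophenyl in place of methyl on a saturated chain carbon bound to an aromatic nitrogen. The two measured steps that bear on it, from compound 1 to compound 2 and from compound 1 to compound 3, both put a larger group on the same saturated chain carbon bound to an aromatic nitrogen, and both moved the number upward by about the same amount, close to the upper end of the scale. A similar upward step is therefore expected here, small because compound 3 already gives 98%.

The expected step is a number 8 percentage points higher from compound 1 to compound 4 (within the scatter). Compound 4 is thus estimated at 95%, with a range from 85% to 100%.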

Compound 4, a percentage reported as inhibition, at one concentration (the size of the read-out at that concentration, not a potency): 95%
Compound 4: the middle estimate sits on the measured number at the digits printed; the range from low to high includes it.
By their numbers in this assay, from the lowest: compounds 1, 4, 2 and 3 (each within the scatter of the next, the first and the last beyond it).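

Among the compounds shown here, this is the first aromatic ring at this position, and in this assay the change from ethyl to 3-chlorobenzyl gives a number 8 percentage points higher from compound 1 to compound 4 (within the scatter) and so, unlike the cyclohexylmethyl group of compound 3, leaves compound 4 not separable from compound 1. Compared with the saturated rings, the aromatic ring with its chlorine also makes no readable difference, with a number 3 percentage points lower from compound 3 to compound 4 (within the scatter) and a number 2 percentage points lower from compound 2 to compound 4 (within the scatter) on the two comparisons, so a saturated or an aromatic carbon ring can stand here without a step beyond the scatter. Nothing measured here explains why these groups behave alike.

A plain benzyl group would show what the chlorine adds. An amine or a carboxylic acid on the chain in this place remains an open case, and so does a ring containing nitrogen.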